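The source may hold more compounds than are shown below. What is called first, only, known or untested is meant among the compounds shown, and "the series" means these compounds.

Working notes on the series, followed in a functional assay on KOPN-8 cells (Homo sapiens) for antiproliferative activity, with a stated time of 72 h; a lower number here means that less compound is needed, a higher number that more compound is needed for the effect. Compound 1 `COc1ccc(-c2c(Cl)c(=O)c3c(OC)cc(OC)cc3n2S(=O)(=O)c2ccc(OC)cc2)cc1` gives 19100 nM in this assay. Going by the values given here, compound 2 `COC(=O)c1cc(=O)c2cc(NC(=O)Nc3ccc(F)c(Cl)c3)ccc2[nH]1` shares no single point of difference with compound 1, so no step between them is computed; of the two values in hand, one is a number and one is a bound. For compound 2 this assay reports only a limit, > 6350 nM, so where compound 2 stands is known only as that bound and not as a number. This is the bound described by the limit of > 6350 nM in this assay, at which 1 of the 2 values shown sits.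

Compound 3 `COC(=O)c1cc(=O)c2cc(NC(=O)NCc3ccccc3)ccc2[nH]1` is the next member. Its change from compound 2 is benzyl in place of 3-chloro-4-fluorophenyl on an amide-type nitrogen, a benzyl in place of 3-chloro-4-fluorophenyl on an amide-type nitrogen. Among the compounds with values here, no step between measured compounds is available, so nothing in the data sets the size or the direction of this change. With compound 2 standing at a limit, compound 3 is expected to stay weak, the step that the limit leaves unreadable from compound 2 to compound 3 being the expectation rather than a measured shift. For compound 3 the estimated value is 12000 nM, with an expected range from 4000 nM to 40000 nM, and a further limit rather than a number is the likelier outcome.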

Compound 3, half-maximal effective concentration: > 19500 nM
Compound 3 ended at the assay's limit; the forecaster's own chance of this, stated with the estimate: 70%; middle value at least 1.6-fold (0.21 log units) from the limit.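

Going by these compounds alone, compound 2 and compound 3 both stand at limits of this assay and not at numbers, and no step between the two can be read. The compounds shown leave open whether benzyl in place of 3-chloro-4-fluorophenyl on an amide-type nitrogen shifts the value in this assay at all, and in which direction.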